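The source may report more compounds than this note shows. Statements on the series, on what has been measured and on what is new or still open speak of the compounds shown alone.

Compound 1 `CS/C(=N\C(=O)c1sccc1Cl)NC(=O)c1sccc1Cl` is the parent of the pair examined here. In a functional assay on MCF7 cells (Homo sapiens) for cytotoxicity, read by MTT assay, with a stated time of 72 h (a lower number here means that less compound is tolerated, a higher number that more compound is tolerated), compound 1 gives only a limit of the assay, > 100000 nM. Compound 2 `CS/C(=N\C(=O)c1cccs1)NC(=O)c1cccs1` likewise gives only a limit in this assay, > 100000 nM. For the measured compounds named here, both measured values therefore sit at the same point, (the limit of > 100000 nM in this assay, at which 2 of the 2 values shown sit), and no step between measured compounds can be read. Compound 3 `C[Se]/C(=N\C(=O)c1sccc1Cl)NC(=O)c1sccc1Cl` differs from compound 1 in one place: a group of 2 heavy atoms (1 carbon, 1 selenium; no ring) in place of a group of 2 heavy atoms (1 carbon, 1 sulfur; no ring), on a carbon with a double bond to nitrogen. Going by the values given here, no measured step bears on this change, so no shift beyond the scatter is expected in this assay. Compound 3 is accordingly estimated at 100000 nM, range 50000 nM to 200000 nM, and most likely again reported only as a limit. The expected step from compound 1 to compound 3 is a number no higher from compound 1 to compound 3 (the limit leaves the size open).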

Compound 3, concentration lethal to 50% of the cells: > 100000 nM
Compound 3: a limit, no number; the forecaster's own chance of this, stated with the estimate: 80%; the middle value lies on the limit itself.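

Compound 1 and compound 3 both stand at a limit in this assay, so no step between them can be read: the limit of > 100000 nM in this assay, at which 3 of the 3 values shown sit.

From the compounds shown here alone, whether selenium in place of sulfur changes the cytotoxicity of the shared core remains open.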